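The source may report more compounds than this note shows. Statements on the series, on what has been measured and on what is new or still open speak of the compounds shown alone.

Measured compounds in a functional assay on HCT-116 cells (Homo sapiens) for antiproliferative activity, read by MTT assay, with a stated time of 72 h; on this read-out lower numbers stand for stronger inhibition and higher numbers for weaker inhibition:
Compound 1 `CN(C(=O)c1ccc(Cl)cc1)c1ccc2[nH]c(-c3n[nH]c4ccccc34)cc2n1`: 3000 nM
Compound 2 `CN(c1ccc2[nH]c(-c3n[nH]c4ccccc34)cc2n1)S(=O)(=O)c1ccccc1`: 6740 nM

For the measured compounds named here, compound 1 holds the lowest number of the two; compound 2 sits a 2.2-fold higher number from compound 1 to compound 2 (0.35 log units; beyond the scatter), the sole step so far, in which a phenylsulfonyl replaces the (4-chlorophenyl)carbonyl on a nitrogen on an aromatic ring.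

Compound 3 `COc1ccc(NC(=O)N(C)c2ccc3[nH]c(-c4n[nH]c5ccccc45)cc3n2)cc1` is not yet measured. It keeps the carbonyl of compound 1 and differs from it as follows: (4-methoxyphenyl)amino in place of 4-chlorophenyl on a carbonyl carbon. Going by the values given here, no measured pair varies this position on the carbonyl carbon, so the step from compound 1 to compound 2 is the only guide, and it concerns the group on the nitrogen rather than on the carbonyl carbon; it shows that a single change at this end of the core moved the number by a modest margin and in the weaker direction. The expectation for compound 3 is therefore a small step, most likely no larger than that one, with no firm direction; the estimated step is a 1.2-fold higher number from compound 1 to compound 3 (0.07 log units; within the scatter). Compound 3 is estimated at 3500 nM, with a range from 1200 nM to 10000 nM.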

Compound 3, half-maximal inhibitory concentration: 63 nM
Compound 3: the middle estimate sits 56-fold (1.74 log units) above what was measured; measured number below the stated range.
By their numbers in this assay, from the lowest: compound 3; then compound 1; then compound 2.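

In this assay, the group on the carbonyl carbon is a far stronger handle on the number than the earlier comparison could indicate: the step of a 48-fold lower number from compound 1 to compound 3 (1.68 log units; beyond the scatter) greatly exceeds the step of a 2.2-fold higher number from compound 1 to compound 2 (0.35 log units; beyond the scatter) made on the nitrogen. The change brings in an amino nitrogen on the carbonyl carbon, with the aromatic ring kept, so the count moves to one hydrogen-bond donor and one hydrogen-bond acceptor where 4-chlorophenyl has none, and the chlorine gives way to a methoxy group in the same exchange. No measurement shown explains the gain in terms of any property of the entering group, and nothing shown addresses how it arises.

For the compounds shown here, the single step joins two changes, so the share of the amino nitrogen and the share of the methoxy group remain unseparated; (4-chlorophenyl)amino or plain phenylamino on the same carbonyl carbon would divide them. Also open, on these data alone, is how far the ring can be varied at this place, for instance whether a morpholine, a longer alkyl chain or a carboxylic acid in place of the methoxy group would hold a number like that of compound 3.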